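A few compounds are considered here, and "the series" means these few. Any claim that something is new, unique, unknown or untested is made for them only; others in the source may bear on it.

Among the compounds with values here, in an ADME assay on microsomes from liver (Mus musculus) for metabolic stability, read by LC-MS, with a stated time of 30 min, tested at 1 uM (a higher number here means that more of the compound is left, a lower number that less of the compound is left), compound 1 `CC(C)C1=C(C(=O)N2[C@H](C)CC[C@H]2C(=O)N2CCN(C)CC2)SC2=N[C@@](C)(c3ccc(Cl)cc3)[C@@H](c3ccc(Cl)cc3)N21` gives 25%, the higher of the two numbers so far, and compound 2 `CC(=O)N1CCN(C(=O)[C@@H]2CC[C@@H](C)N2C(=O)C2=C(C(C)C)N3C(=N[C@@](C)(c4ccc(Cl)cc4)[C@H]3c3ccc(Cl)cc3)S2)CC1` gives 13%. That only measured step, a number 12 percentage points lower from compound 1 to compound 2 (beyond the scatter), puts acetyl in place of methyl on an amine nitrogen in a ring. It concerns a different place from the change at issue here and offers only a rough gauge of size. Compound 3 `CC[C@@H]1CC[C@@H](C(=O)N2CCN(C)CC2)N1C(=O)C1=C(C(C)C)N2C(=N[C@@](C)(c3ccc(Cl)cc3)[C@H]2c2ccc(Cl)cc2)S1` instead has methyl in place of hydrogen on a saturated chain carbon bound to a saturated ring carbon. The expected outcome is a number 3 percentage points lower from compound 1 to compound 3 (within the scatter), with no clear shift anticipated. For compound 3 the estimated value is 22%, within an expected range of 11% to 34%.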

Compound 3, percent of the compound remaining: 50%
Beside the measured number, compound 3's estimate is 28 percentage points below it; measured number outside the range, above it.
By their numbers in this assay, from the lowest: compound 2; then compound 1; then compound 3.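

Going from methyl to ethyl gives a number 25 percentage points higher from compound 1 to compound 3 (beyond the scatter) in this assay, so a single added carbon on a saturated chain carbon bound to a saturated ring carbon is enough to raise the percent of compound remaining beyond the scatter. Within the data shown here, this is the first reading at this place, and it shows a rise where the earlier step, at the amine nitrogen in a ring, showed a fall. Nothing at hand explains the rise. On these data alone, it remains open whether a longer chain such as propyl would raise the number further, and whether a branched group such as isopropyl would do the same.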